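This account rests on a few compounds, and the source may have more. Where it says the series, first, only, none or still open, it means among the compounds named here.

Working notes on the series, all read in a functional assay on OVCAR-3 cells (Homo sapiens) for antiproliferative activity, read by MTT assay, with a stated time of 24 h; on this read-out higher numbers stand for weaker inhibition and lower numbers for stronger inhibition. Compound 1 `Cc1cccc(NNC(=O)c2cccc(NS(=O)(=O)c3cnc(O)nc3O)c2)c1` reads > 20000 nM, which is a limit of the assay. Compound 2 `O=C(NNc1ccccc1F)c1cccc(NS(=O)(=O)c2cnc(O)nc2O)c1` gives 17000 nM and compound 3 `CCCCOc1ccc(C(=O)NNC(=O)c2cccc(NS(=O)(=O)c3cnc(O)nc3O)c2)cc1` gives 9200 nM, two numbers within the scatter of each other. Compound 4 `O=C(NNC(=O)c1ccccc1Cl)c1cccc(NS(=O)(=O)c2cnc(O)nc2O)c1` carries 2-chlorophenyl in place of 4-butoxyphenyl on a carbonyl carbon. Among the compounds with values here, the only measured step, an at least 1.1-fold lower number from compound 1 to compound 2 (0.07 log units; that floor lies within the scatter), concerns a change on an amine nitrogen, so it bears only loosely on this one and gives no direction. No shift beyond the scatter is therefore expected in this assay. The expected change is a 1.5-fold higher number from compound 3 to compound 4 (0.18 log units; within the scatter). Compound 4 is estimated at 14000 nM, with an expected range of 7000 nM to 28000 nM.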

Compound 4, half-maximal inhibitory concentration: 7300 nM
Compound 4: the middle estimate sits 1.9-fold (0.28 log units) above what was measured; the measured number falls inside the stated range.
By their numbers in this assay, from the lowest: compounds 4, 3 and 2 (each within the scatter of the next, the first and the last beyond it). At a limit, above all of these: compound 1.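

On the carbonyl carbon, 2-chlorophenyl and 4-butoxyphenyl are not told apart in this assay, with a 1.3-fold lower number from compound 3 to compound 4 (0.10 log units; within the scatter). Within the data shown here, putting (2-chlorophenyl)carbonyl in place of 2-fluorophenyl on the amine nitrogen gives the first step that clears the scatter, with a 2.3-fold lower number from compound 2 to compound 4 (0.37 log units; beyond the scatter). The same group in place of 3-methylphenyl gives an at least 2.7-fold lower number from compound 1 to compound 4 (0.43 log units; beyond the scatter), a floor that rests on a limit: the limit of > 20000 nM in this assay, at which 1 of the 4 values shown sits.

Open, going by these compounds, is how unsubstituted phenyl or a simple alkyl chain would read on that carbonyl carbon, and whether any group there moves the number beyond the scatter.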